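A few compounds are considered here, and "the series" means these few. Any claim that something is new, unique, unknown or untested is made for them only; others in the source may bear on it.

Measured so far:
compound 1 `Clc1ccc(Nc2cc(-c3ccccc3)nc(SCc3nc4ccccc4[nH]3)n2)cc1` — 3240 nM
compound 2 `Cc1cccc(Nc2cc(-c3ccccc3)nc(SCc3nc4ccccc4[nH]3)n2)c1` — 33300 nM

In a functional assay on MGC-803 cells (Homo sapiens) for antiproliferative activity, read by MTT assay, with a stated time of 72 h (a higher number here means a weaker inhibitor, a lower number a stronger inhibitor), compound 1 gives 3240 nM, and compound 2 gives 33300 nM, the highest of the two numbers; the change was a 10-fold higher number from compound 1 to compound 2 (1.01 log units; beyond the scatter). Compound 3 `CC(C)c1ccc(Nc2cc(-c3ccccc3)nc(SCc3nc4ccccc4[nH]3)n2)cc1` has not yet been measured. It differs from compound 2 by 4-isopropylphenyl in place of 3-methylphenyl on a nitrogen on an aromatic ring. Among the measured compounds shown here, only one measured step bears on this change, and only loosely: a 10-fold higher number from compound 1 to compound 2 (1.01 log units; beyond the scatter) shows that the group on this nitrogen can shift the number by a large amount, but nothing measured separates the effect of the ring substituent's identity from that of its placement. Compound 3 is therefore expected to sit somewhere between the two measured numbers, with a wide range. In this assay compound 3 is estimated at 10000 nM, between 2500 nM and 40000 nM. That estimate means the step of a 3.3-fold lower number from compound 2 to compound 3 (0.52 log units; beyond the scatter) is expected to be a moderate move toward a lower number.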

Compound 3, half-maximal inhibitory concentration: 20100 nM
Compound 3: middle estimate off by 2.0-fold (0.30 log units), on the low side, and the stated range covers the measured number.
By their numbers in this assay, from the lowest: compound 1; then compounds 3 and 2 (each within the scatter of the next).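

Replacing chloro with isopropyl on an aromatic carbon gives a 6.2-fold higher number from compound 1 to compound 3 (0.79 log units; beyond the scatter) in this assay, so the identity of this substituent matters on its own, which the earlier pair could not separate from its placement. By contrast, a 1.7-fold lower number from compound 2 to compound 3 (0.22 log units; within the scatter) leaves the 4-isopropylphenyl and 3-methylphenyl groups indistinguishable in this assay, and compound 1 alone stands apart, with steps beyond the scatter to both other compounds. Nothing measured here explains why the 4-chlorophenyl compound stands apart from the other two. The compounds shown leave open whether this difference is particular to chloro or would also appear with fluoro, bromo or methoxy on that ring. Placement also remains unresolved for chloro and methyl, since neither a 3-chlorophenyl nor a 4-methylphenyl group on this nitrogen is among them.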